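Amide nitrogen substituent trimming in an alkyne series

A few compounds are considered here, and "the series" means these few. Any claim that something is new, unique, unknown or untested is made for them only; others in the source may bear on it.

Measured compounds:
compound 1 `C[C@H](NC(=O)c1ccc(C#Cc2cccc(F)c2)cn1)C(C)(C)C`: 70.8%
compound 2 `CC(C)[C@H](C)NC(=O)c1ccc(C#Cc2cccc(F)c2)cn1`: 66.7%

Both compounds share the core and differ only in the group on the amide nitrogen. In a functional assay on HEK293 cells for positive allosteric modulation of metabotropic glutamate receptor 5 (Rattus norvegicus), read by fluorescence and calcium flux (on this read-out lower numbers stand for smaller maximal responses and higher numbers for larger maximal responses), compound 1 gives 70.8% and compound 2 gives 66.7%; the step of a number 4.1 percentage points lower from compound 1 to compound 2 (within the scatter), and so compound 2 stands within the scatter of compound 1 and cannot be set apart from it.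

Compound 3 `CCCNC(=O)c1ccc(C#Cc2cccc(F)c2)cn1` is not yet measured. The change is propyl in place of 1,2-dimethylpropyl on an amide-type nitrogen. Within the data shown here, the only measured step, a number 4.1 percentage points lower from compound 1 to compound 2 (within the scatter), also trimmed the chain on this nitrogen, and it stayed within the scatter. On that basis the step to compound 3 is expected to be a number 3.7 percentage points lower from compound 2 to compound 3 (within the scatter), with no change beyond the scatter expected. The estimate for compound 3 is 63%, in the range 45% to 80%.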

Compound 3, largest response reached (reported as efficacy), in percent of the reference or control that the assay uses: 65.9%
Compound 3: middle estimate off by 2.9 percentage points, on the low side; low and high end bracket the measured number.
By their numbers in this assay, from the lowest: compounds 3, 2 and 1 (each within the scatter of the next).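

In this assay, the change to propyl on the amide-type nitrogen gives a number 0.8 percentage points lower from compound 2 to compound 3 (within the scatter) and the full trimming from 1,2,2-trimethylpropyl gives a number 4.9 percentage points lower from compound 1 to compound 3 (within the scatter) so the read-out does not separate any of the three groups. The earlier pair covered only the loss of one methyl with the defined stereocentre kept, whereas propyl carries no stereocentre and has two fewer carbons than 1,2-dimethylpropyl, and the maximal response still stays within the scatter. No supporting data bear on why the response holds across these groups.

Open, on these data alone, is how far the trimming can go: whether ethyl, methyl or the bare amide hydrogen keeps the response on this nitrogen. Also open, as far as these compounds go, is whether a chain carrying a hydroxyl or an amine, or a ring such as cyclopropyl, would move the number beyond the scatter.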